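The source may report more compounds than this note shows. Statements on the series, on what has been measured and on what is new or still open speak of the compounds shown alone.

In a functional assay on A-375 cells (Homo sapiens) for antiproliferative activity, read by CCK-8 assay, with a stated time of 72 h, tested at 2 uM (a lower number here means a weaker effect, a higher number a stronger effect of the compound at the concentration tested), compound 1 `CN(Cc1ccncc1)C(=S)SCc1ccc(C(=O)Nc2ccccc2N)cc1` gives 31.4%. Compound 2 `Nc1ccccc1NC(=O)c1ccc(CSC(=S)N2CCN(c3ccc(F)cc3)CC2)cc1` stands lowest of the two numbers shown: in this assay compound 2 gives 20.9%, a gap to compound 1 that lies beyond the usual scatter. Compound 3 `N#Cc1ccc(N2CCN(C(=S)SCc3ccc(C(=O)Nc4ccccc4N)cc3)CC2)cc1` differs from compound 2 in one place: cyano in place of fluoro on an aromatic carbon. Among the measured compounds shown here, no measured pair here shows what such a swap does on this core, so the step from compound 2 to compound 3 is expected to be small, in no sure direction, and likely within the scatter: a number 2.1 percentage points higher from compound 2 to compound 3 (within the scatter). For compound 3 the expected value in this assay is 23%, in a range from 10% to 38%.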

Compound 3, a percentage reported as inhibition, at one concentration (the size of the read-out at that concentration, not a potency): 41.4%
For compound 3 the middle estimate is 18.4 percentage points below the measured one, and the stated range ends below it.
By their numbers in this assay, from the lowest: compound 2; then compounds 1 and 3 (each within the scatter of the next).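

In this assay, among the compounds shown here, the change from 4-fluorophenyl to 4-cyanophenyl gives a number 20.5 percentage points higher from compound 2 to compound 3 (beyond the scatter) on the same core, the first pair here that differs in one place. It shows that the group at this position on the aromatic ring can shift the read-out by more than ordinary scatter. No measured evidence here explains this step. Going by these compounds, whether an amine, a carboxylic acid or a methoxy group at this place would give a similar shift stays open. A single pair also cannot show whether this swap would act alike on another core.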